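A Vinyl for a Methyl on the Outer Ring

The source may report more compounds than this note shows. Statements on the series, on what has been measured and on what is new or still open speak of the compounds shown alone.

Compound 1 `COc1cc(-c2ccnc3cc(-c4ccc(C)cc4)nn23)cc(OC)c1OC` is the reference point of this set. In a functional assay on B16-F0 cells (Mus musculus) for inhibition, read by CCK-8 assay, with a stated time of 48 h (on this read-out higher numbers stand for weaker inhibition and lower numbers for stronger inhibition), compound 1 gives 21 nM, the lowest number of the three measured compounds. Compound 2 `COc1cc(-c2ccnc3cc(-c4ccccc4)nn23)cc(OC)c1OC` gives 4730 nM, and compound 3 `COc1cc(-c2ccnc3cc(-c4cn(C)c5ccccc45)nn23)cc(OC)c1OC` gives 185 nM. The step of a 230-fold higher number from compound 1 to compound 2 (2.35 log units; beyond the scatter) shows that simply stripping the methyl from the outer ring costs a great deal. The step of an 8.8-fold higher number from compound 1 to compound 3 (0.94 log units; beyond the scatter) shows a smaller loss when the whole 4-methylphenyl is exchanged for 1-methyl-1H-indol-3-yl, and the step of a 26-fold lower number from compound 2 to compound 3 (1.41 log units; beyond the scatter) shows that this larger group recovers much of what the bare phenyl lost.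

Compound 4 `C=Cc1ccc(-c2cc3nccc(-c4cc(OC)c(OC)c(OC)c4)n3n2)cc1` differs from compound 1 in one place: vinyl in place of methyl on an aromatic carbon. The change keeps a small carbon group at the position para to a large group, where the result for compound 2 shows that an empty position is strongly disfavoured. Among the compounds with values here, no measured step tests a vinyl in this position, so the expectation rests on the vinyl being a near neighbour of the methyl rather than its removal.

For compound 4 the expected step is a 1.7-fold higher number from compound 1 to compound 4 (0.22 log units; within the scatter), that is, little change beyond the scatter, with a slight lean toward weaker inhibition. Compound 4 is therefore estimated at 35 nM, within the range 10 nM to 150 nM.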

Compound 4, half-maximal inhibitory concentration: 788 nM
Estimate against measurement, compound 4: 23-fold (1.35 log units) below, and the stated range ends below it.
By their numbers in this assay, from the lowest: compound 1; then compound 3; then compound 4; then compound 2.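

In this assay, this position proves far more selective than a simple choice between filled and empty, as a 38-fold higher number from compound 1 to compound 4 (1.57 log units; beyond the scatter) shows that methyl and vinyl are not interchangeable here. Vinyl still retains part of what the outer ring can gain from a group at this place, since a 6.0-fold lower number from compound 2 to compound 4 (0.78 log units; beyond the scatter) marks a clear improvement over plain hydrogen, but a 4.3-fold higher number from compound 3 to compound 4 (0.63 log units; beyond the scatter) places the 4-vinylphenyl compound behind the one carrying 1-methyl-1H-indol-3-yl. Nothing in the available information explains why replacing methyl with vinyl has such a large effect on this read-out.

The compounds shown leave open whether the double bond itself matters, a question that an ethyl group at the same place could help to answer by keeping the same number of carbons while removing the double bond. They also leave open how groups of other kinds, such as a methoxy group or an amine, would compare with methyl here, and so how narrow the preference at this position really is.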